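A few compounds are considered here, and "the series" means these few. Any claim that something is new, unique, unknown or untested is made for them only; others in the source may bear on it.

Measured so far:
compound 1, `COc1ccccc1-c1cccc(S(=O)(=O)N2CCC(N3CCC(C)CC3)CC2)c1`: 21 nM
compound 2, `CC1CCN(C2CCN(S(=O)(=O)c3ccc(F)cc3F)CC2)CC1`: 102 nM
compound 3, `CC1CCN(C2CCN(S(=O)(=O)c3ccc(Br)cc3OC(F)(F)F)CC2)CC1`: 5 nM

All three were read in a functional assay on DLD-1 cells (Homo sapiens) for antiproliferative activity, read by CellTiter-Glo, with a stated time of 72 h; a lower number here means a stronger inhibitor, a higher number a weaker inhibitor. Compound 2 gives the highest number of the three; compound 1 sits below it by a gap beyond the scatter, and compound 3 further below, also beyond the scatter. Among the measured compounds shown here, no single-point step between measured compounds is available, so the change to compound 4, `CC1CCN(C2CCN(S(=O)(=O)c3cncc(Br)c3)CC2)CC1`, rests on the structures alone. The change: 5-bromopyridin-3-yl in place of 2,4-difluorophenyl on a sulfonyl sulfur. For the measured compounds named here, compound 3 also carries a bromine and gives 5 nM, the lowest number in this set; the ring nitrogen has no measured counterpart. The step from compound 2 to compound 4 is expected to be a 2.0-fold lower number from compound 2 to compound 4 (0.31 log units; beyond the scatter), toward a lower number, and may not exceed the scatter. Compound 4 is estimated at 50 nM (range 15 nM to 200 nM).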

Compound 4, half-maximal inhibitory concentration: > 5000 nM
Compound 4 gave a limit, no number; the forecaster's own chance of this, stated with the estimate: 3%; middle value at least 100-fold (2.00 log units) from the limit.
By their numbers in this assay, from the lowest: compound 3; then compound 1; then compound 2. At a limit, above all of these: compound 4.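

Compound 4 gives a limit, not a number: the limit of > 5000 nM in this assay, at which 1 of the 4 values shown sits. Placing 5-bromopyridin-3-yl in place of 2,4-difluorophenyl on the sulfonyl sulfur gives an at least 49-fold higher number from compound 2 to compound 4 (1.69 log units; beyond the scatter), so the group at this position alone can decide activity on the shared core. Bromine on the ring secures nothing by itself: compound 3 carries bromine and gives 5 nM. Compound 4 also carries bromine and reaches only its limit.

The compounds shown do not separate the contribution of the ring nitrogen from that of the bromine. A pyridin-3-yl or 3-bromophenyl group on the sulfonyl sulfur would separate the two.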